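Chloro added beside the trifluoromethyl anilide of compound 1

The source may report more compounds than this note shows. Statements on the series, on what has been measured and on what is new or still open speak of the compounds shown alone.

Compound 1 `O=C(Nc1cccc(-n2cc(-c3ccncc3)c(-c3ccc(Cl)c(O)c3)n2)c1)Nc1cccc(C(F)(F)F)c1` is the weaker of the two measured growth inhibitors: in a functional assay on A549 cells (Homo sapiens) for inhibition, read by sulforhodamine B assay, with a stated time of 48 h (a higher number here means a weaker inhibitor of growth, a lower number a stronger inhibitor of growth), compound 1 gives 1370 nM, while compound 2 `O=C(Nc1cccc(-n2cc(-c3ccncc3)c(-c3ccc(Cl)c(O)c3)n2)c1)Nc1cc(C(F)(F)F)cc(C(F)(F)F)c1` gives 298 nM. Within the data shown here, the one measured step, a 4.6-fold lower number from compound 1 to compound 2 (0.66 log units; beyond the scatter), shows that adding a second trifluoromethyl to the terminal anilide ring lowers the number well beyond the scatter. Compound 3 `O=C(Nc1cccc(-n2cc(-c3ccncc3)c(-c3ccc(Cl)c(O)c3)n2)c1)Nc1ccc(Cl)c(C(F)(F)F)c1` carries a different change on that same ring: chloro in place of hydrogen on an aromatic carbon. Among the measured compounds shown here, no measured step concerns a chloro at this position, so the trifluoromethyl step is the only guide, and a halogen is a smaller addition than a trifluoromethyl. A step of modest size, in the same direction as from compound 1 to compound 2, is therefore expected, a 2.5-fold lower number from compound 1 to compound 3 (0.40 log units; beyond the scatter). Compound 3 is expected to give about 550 nM in this assay, within a range from 200 nM to 1500 nM.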

Compound 3, concentration for 50% growth inhibition: 927 nM
For compound 3 the middle estimate is 1.7-fold (0.23 log units) below the measured one; low and high end bracket the measured number.
By their numbers in this assay, from the lowest: compound 2; then compounds 3 and 1 (each within the scatter of the next).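

Chloro on the aromatic carbon ortho to the trifluoromethyl group and para to a large group gives a 1.5-fold lower number from compound 1 to compound 3 (0.17 log units; within the scatter) in this assay, so this addition to the terminal ring cannot be told apart from no change. The earlier step, a 4.6-fold lower number from compound 1 to compound 2 (0.66 log units; beyond the scatter), therefore does not extend to every addition on this ring, although that step and the chloro step differ in both the entering group and its place, so neither factor can be isolated from this pair. No measured evidence bears on the origin of this result.

As far as these compounds go, it remains open whether another group on the same carbon, such as an amine, a methoxy group or a carboxylic acid, would move the number beyond the scatter. Also open, from the compounds shown here alone, is whether chloro at this position would behave the same way in a compound carrying a second trifluoromethyl group.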